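The source may report more compounds than this note shows. Statements on the series, on what has been measured and on what is new or still open speak of the compounds shown alone.

Working notes on the series. All compounds share one core and differ only in the group on the amide-type nitrogen. For the measured compounds named here, in an assay on isolated protein for inhibition of tyrosine-protein phosphatase non-receptor type 13 (Homo sapiens), read by spectrophotometry (on this read-out lower numbers stand for stronger inhibition and higher numbers for weaker inhibition), compound 3 `Cc1ccc(S(=O)(=O)NNC(=O)COc2ccc3cc(C(O)(C(F)(F)F)C(F)(F)F)c(O)cc3c2)cc1` gives 14900 nM, the only actual number in the set. For compound 1 `O=C(COc1ccc2cc(C(O)(C(F)(F)F)C(F)(F)F)c(O)cc2c1)Nc1ccccc1` the read-out in this assay is a limit of the assay, > 20000 nM. For compound 2 `CCCNC(=O)COc1ccc2cc(C(O)(C(F)(F)F)C(F)(F)F)c(O)cc2c1` the read-out in this assay is likewise a limit, > 20000 nM. The measured steps are an at least 1.3-fold lower number from compound 1 to compound 3 (0.12 log units; that floor lies within the scatter) and an at least 1.3-fold lower number from compound 2 to compound 3 (0.12 log units; that floor lies within the scatter), each setting only a floor; the step that the two limits leave unreadable from compound 1 to compound 2 cannot be read. Compound 4 `O=C(COc1ccc2cc(C(O)(C(F)(F)F)C(F)(F)F)c(O)cc2c1)Nc1cccc2ccccc12` is not yet measured; the change is naphthalen-1-yl in place of ((4-methylphenyl)sulfonyl)amino on an amide-type nitrogen. The step with an aromatic group in place of the sulfonylamino group, an at least 1.3-fold lower number from compound 1 to compound 3 (0.12 log units; that floor lies within the scatter), shows no readable gain, and two of the three values sit at the limit of > 20000 nM in this assay, at which 2 of the 3 values shown sit. Compound 4 is therefore expected to stay near that limit, the expected step being a 1.5-fold higher number from compound 3 to compound 4 (0.17 log units; within the scatter). The estimate for compound 4 in this assay is 22000 nM, with a range from 8000 nM to 60000 nM, and a limit rather than a number is the likelier outcome.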

Compound 4, half-maximal inhibitory concentration: > 20000 nM
Compound 4 was reported as a limit; the forecaster's own chance of this, stated with the estimate: 60%; the middle value is on the limit's open side.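

Putting naphthalen-1-yl in place of ((4-methylphenyl)sulfonyl)amino on the amide-type nitrogen gives an at least 1.3-fold higher number from compound 3 to compound 4 (0.12 log units; that floor lies within the scatter) in this assay, so this change shows no readable loss or gain. Compound 1 with one aromatic ring and compound 4 with two both read as limits, so the second ring brings no readable inhibition, and the steps among compound 1, compound 2 and compound 4 cannot be read. The limit now holds most of the series: the limit of > 20000 nM in this assay, at which 3 of the 4 values shown sit.

Going by these compounds, each step from compound 3 sets only a floor, so the true size of any difference between it and the other compounds stays open. Also open, on these data alone, is how a methanesulfonylamino group, an amine, a carboxylic acid or a longer chain on this nitrogen would read.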